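The compounds below may be only part of what the source reports. "The series", "measured", "known", "first", "only" and "open" are said of these compounds alone.

Of the compounds shown here, two have so far been measured in a functional assay on the whole organism (Tail, strain ICR) with Mus musculus as the target, in the tail flick test, with a stated time of 30 min, at a dose of 25 umol/kg by the oral route; a lower number here means a weaker effect, a higher number a stronger effect of the compound at the dose given. Compound 1 `C[C@@H](O)[C@H](NC(=O)CN(c1nc(Cl)nc2[nH]cnc12)C1CC1)C(=O)O` gives 18.6%, and compound 2 `CC(C)[C@H](NC(=O)CN(c1nc(Cl)nc2[nH]cnc12)C1CC1)C(=O)O` gives 31.2%. Compound 2 holds the higher of the two numbers; its nearest neighbour is compound 1, reached by the step of a number 12.6 percentage points higher from compound 1 to compound 2 (beyond the scatter). Compound 3 `CC(C)C[C@H](NC(=O)CN(c1nc(Cl)nc2[nH]cnc12)C1CC1)C(=O)O` has not yet been measured. It differs from compound 2 in one place: isobutyl in place of isopropyl on a saturated chain carbon bound to an amide-type nitrogen and a carbonyl carbon. For the measured compounds named here, the single measured step bears on this only loosely, because a number 12.6 percentage points higher from compound 1 to compound 2 (beyond the scatter) came from exchanging 1-hydroxyethyl for isopropyl at the same saturated chain carbon, whereas the new exchange is isopropyl for isobutyl. Going by the values given here, no measured pair shows what lengthening that group by one carbon does. The account therefore expects only a small step of a number 3.8 percentage points higher from compound 2 to compound 3 (within the scatter), upward or none beyond the scatter. Compound 3 is estimated at 35%, within a range from 20% to 52%.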

Compound 3, a percentage reported as activity, at one dose (the size of the read-out at that dose, not a potency): 23.4%
Compound 3: the middle estimate sits 11.6 percentage points above what was measured; measured number inside the range.
By their numbers in this assay, from the lowest: compounds 1, 3 and 2 (each within the scatter of the next, the first and the last beyond it).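

In this assay, putting isobutyl in place of isopropyl on the saturated chain carbon bound to an amide-type nitrogen and a carbonyl carbon amounts to a number 7.8 percentage points lower from compound 2 to compound 3 (within the scatter) and shows that this added carbon has no effect that can be told from the scatter. Isobutyl in place of 1-hydroxyethyl at the same carbon comes to a number 4.8 percentage points higher from compound 1 to compound 3 (within the scatter) so compound 3 cannot be separated from either neighbour, and only the step of a number 12.6 percentage points higher from compound 1 to compound 2 (beyond the scatter) remains resolved at this position. Nothing at hand explains these numbers.

From the compounds shown here alone, whether a longer chain or an amine on this carbon would stand clearly apart from compound 2 stays open. Also open, going by these compounds, is whether the same picture would hold at other doses or times.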